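The compounds below may be only part of what the source reports. "The series", "measured", "known", "first", "only" and "open" are said of these compounds alone.

Of the compounds shown here, two sharing one core have been measured so far. Compound 1, `Cc1ccsc1-c1cc(-c2ccco2)cc(-c2ccc(Cl)cc2)n1`, gives in a functional assay on K562 cells (Homo sapiens) for cytotoxicity, read by ELISA, with a stated time of 4 days (on this read-out higher numbers stand for weaker inhibition and lower numbers for stronger inhibition), a value of 20700 nM. Compound 2, `Clc1ccc(-c2cc(-c3ccoc3)cc(-c3ccco3)n2)s1`, gives in this assay a value of 16200 nM. Compound 2 holds the lower of the two numbers, yet the two values lie within the usual scatter of each other, so nothing separates compound 1 from compound 2 on this read-out; both sit in the same weak region.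

Compound 3, `Clc1ccc(-c2cc(-c3ccoc3)cc(-c3cccnc3)n2)s1`, is the next compound to be tested. Relative to compound 2 the change is pyridin-3-yl in place of furan-2-yl on an aromatic carbon. Within the data shown here, no pair of measured compounds shows this change, so there is no measured step to lean on, and the only guide is that the two measured compounds, which differ from each other in more than one place, give values within the scatter of each other. The expected step from compound 2 to compound 3 is a 1.0-fold higher number from compound 2 to compound 3 (0.02 log units; within the scatter), that is, none beyond the scatter. Compound 3 is accordingly expected to give 17000 nM, with a range from 6000 nM to 45000 nM in this assay.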

Compound 3, half-maximal inhibitory concentration: 18700 nM
Estimate against measurement, compound 3: 1.1-fold (0.04 log units) below; the range from low to high includes it.
By their numbers in this assay, from the lowest: compounds 2, 3 and 1 (each within the scatter of the next).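

Among these compounds, this is the first single-place step: on the aromatic carbon next to the ring nitrogen, pyridin-3-yl in place of furan-2-yl gives a 1.2-fold higher number from compound 2 to compound 3 (0.06 log units; within the scatter) in this assay. At this position, then, a six-membered aromatic ring with a ring nitrogen can stand where a five-membered aromatic ring with a ring oxygen stood, with no difference beyond the scatter on this read-out. The finding is narrow: it holds with the furan-3-yl and 5-chlorothiophen-2-yl groups kept in place, and the pair stays in the same weak region, with compound 2 at 16200 nM and compound 3 at 18700 nM.

On these data alone, whether an amine, a carboxylic acid or a longer alkyl chain on this carbon would give a number beyond the scatter stays open, as does what single changes at the furan-3-yl or 5-chlorothiophen-2-yl groups would do with this position held fixed. Nothing available explains why these two rings read alike in this assay.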